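The source may report more compounds than this note shows. Statements on the series, on what has been measured and on what is new or still open speak of the compounds shown alone.

Compound 1 `CC(C)(C)c1ccc(S(=O)(=O)Nc2ccnc(Nc3ccc(C#N)cc3)c2)cc1`: 29300 nM
Compound 2 `N#Cc1ccc(Nc2cc(NS(=O)(=O)c3ccc(F)cc3)ccn2)cc1`: 6120 nM
Compound 3 `CC(C)(C)c1ccc(S(=O)(=O)Nc2ccnc(Nc3ccc(C#N)cc3)n2)cc1`: 30300 nM

These three compounds were tested in an ADME assay on MT4 cells (Homo sapiens) for cytotoxicity, read by MTT assay, with a stated time of 5 days (a lower number here means that less compound is tolerated, a higher number that more compound is tolerated), where compound 1 gives 29300 nM, compound 2 gives 6120 nM and compound 3 gives 30300 nM. The difference between the core of compound 1 and the core of compound 3 is not broken down here; their two values lie within the usual scatter of each other, so nothing separates them in this assay.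

Between compound 1 and compound 2 the change is fluoro in place of tert-butyl on an aromatic carbon. In this assay this produced a 4.8-fold lower number from compound 1 to compound 2 (0.68 log units; beyond the scatter), a step beyond the scatter, meaning that less of compound 2 is tolerated by the cells than of compound 1.

Compound 4 `N#Cc1ccc(Nc2nccc(NS(=O)(=O)c3ccc(F)cc3)n2)cc1` has not yet been measured. It differs from compound 3 by fluoro in place of tert-butyl on an aromatic carbon. The place of the change is described in exactly the same words for both pairs, so this is the same change made on the core of compound 3 rather than on the core of compound 1.

Among the compounds with values here, because the same change gave a 4.8-fold lower number from compound 1 to compound 2 (0.68 log units; beyond the scatter), the step from compound 3 to compound 4 is expected to be of similar size, a 4.8-fold lower number from compound 3 to compound 4 (0.68 log units; beyond the scatter); this rests only on the one earlier example, so the expectation is loose. For compound 4 the estimated value in this assay is 6300 nM, with a likely range from 2500 nM to 16000 nM.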

Compound 4, half-maximal cytotoxic concentration: 36600 nM
The estimate for compound 4 lay 5.8-fold (0.76 log units) below the measured number, outside the stated range (above it).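

In this assay, the swap of tert-butyl for fluoro behaved differently on the two cores. On the core of compound 3 it gave a 1.2-fold higher number from compound 3 to compound 4 (0.08 log units; within the scatter), so the cells tolerate the two compounds to an extent that cannot be told apart, and the drop seen on the core of compound 1 does not return. The two steps can therefore be said to disagree, and the size of this change cannot simply be carried from one core to the other in this series: the same change on two cores in this assay, a 4.8-fold lower number (0.68 log units; beyond the scatter) from compound 1 to compound 2 and a 1.2-fold higher number (0.08 log units; within the scatter) from compound 3 to compound 4, 5.8-fold (0.76 log units) apart, beyond the scatter of two such steps

This does not show why the two cores respond differently, and with a single pair on each core it cannot show which core's behaviour is the more typical for other swaps. The compounds shown leave open how a methoxy group, a chlorine atom, an amine or a carboxylic acid in place of the tert-butyl or fluoro group would behave on each core. They also leave open whether a second such swap would again differ between the two cores, or whether this disagreement is confined to tert-butyl and fluoro.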